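One Aryl Swap, Measured Once and Repeated on Another Core

The source may hold more compounds than are shown below. What is called first, only, known or untested is meant among the compounds shown, and "the series" means these compounds.

Measured in a functional assay on DU-145 cells (Homo sapiens) for cytotoxicity, read by MTT assay, with a stated time of 48 h; on this read-out lower numbers stand for stronger inhibition and higher numbers for weaker inhibition:
compound 1 `COc1cccc(-n2cc(CO/N=C3\CC[C@]4(C)[C@@H](CC/C=C(\C)CC/C=C(\C)CCC=C(C)C)[C@](C)(O)CC[C@H]4C3(C)C)nn2)c1` gives 30500 nM
compound 2 `CC(C)=CCC/C(C)=C/CC/C(C)=C/CC[C@@H]1[C@@]2(C)CC/C(=N\OCc3cn(-c4ccc(F)cc4)nn3)C(C)(C)[C@@H]2CC[C@@]1(C)O` gives 21600 nM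
compound 3 `COc1cccc(-n2cc(COc3ccc(/C=C4\C[C@]5(C)[C@@H](CC/C=C(\C)CC/C=C(\C)CCC=C(C)C)[C@](C)(O)CC[C@H]5C(C)(C)C4=O)cc3)nn2)c1` gives 14500 nM

Compound 1 and compound 2 differ in one place: 4-fluorophenyl in place of 3-methoxyphenyl on an aromatic nitrogen. That change gave a 1.4-fold lower number from compound 1 to compound 2 (0.15 log units; within the scatter). Compound 4 `CC(C)=CCC/C(C)=C/CC/C(C)=C/CC[C@@H]1[C@@]2(C)C/C(=C\c3ccc(OCc4cn(-c5ccc(F)cc5)nn4)cc3)C(=O)C(C)(C)[C@@H]2CC[C@@]1(C)O`, not yet measured, carries the same change made on the core of compound 3: 4-fluorophenyl in place of 3-methoxyphenyl on an aromatic nitrogen. The cores of compound 1 and compound 3 differ in more than one place, and that difference is not broken down here. Compound 3 sits beyond the scatter from compound 1 but within it from compound 2. Because the earlier step of a 1.4-fold lower number from compound 1 to compound 2 (0.15 log units; within the scatter) stayed within the scatter, a step of similar size is expected here, a 1.4-fold lower number from compound 3 to compound 4 (0.14 log units; within the scatter). Compound 4 is therefore estimated at 10500 nM, with a likely range from 5000 nM to 25000 nM.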

Compound 4, half-maximal inhibitory concentration: 33600 nM
Beside the measured number, compound 4's estimate is 3.2-fold (0.51 log units) below it, and the stated range ends below it.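

In this assay the swap to 4-fluorophenyl from 3-methoxyphenyl gave a 2.3-fold higher number from compound 3 to compound 4 (0.36 log units; beyond the scatter) on the second core, so the number rose there instead of staying level. The change therefore did not carry over unchanged from one core to the other, and its effect depended on the core it was made on: the same change on two cores in this assay, a 1.4-fold lower number (0.15 log units; within the scatter) from compound 1 to compound 2 and a 2.3-fold higher number (0.36 log units; beyond the scatter) from compound 3 to compound 4, 3.3-fold (0.51 log units) apart, beyond the scatter of two such steps. With only these two pairs, this does not show which part of the cores accounts for the gap, or how the change would behave on any other core.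

The compounds shown leave open how other groups on that aromatic nitrogen would behave on both cores, such as a plain phenyl, a benzyl or a phenyl bearing an amine or a carboxylic acid. They also leave open whether any such group would give matching steps on the two cores.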